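Swapping a fluorophenyl for a thiazole on a cyclopropane

The source may hold more compounds than are shown below. What is called first, only, known or untested is meant among the compounds shown, and "the series" means these compounds.

Among the measured compounds shown here, compound 3 `CC[C@H](C)[C@H](N)CN(C(=O)[C@@H]1C[C@H]1c1cccc(F)c1)c1ccc(-c2ccccc2)cc1` gives 560 nM in a functional assay for agonist activity at G protein-coupled receptor 88 (Homo sapiens), read by HTRF and cAMP accumulation (a lower number here means that less compound is needed, a higher number that more compound is needed for the effect), the highest of the three numbers measured so far, beyond the scatter above both compound 2 `CC(C)C[C@@H](N)CN(C(=O)[C@@H]1C[C@H]1c1ccccc1)c1ccc(-c2ccccc2)cc1`, which gives 1.8 nM, and compound 1 `CC(C)C[C@H](N)CN(C(=O)C(C)Cc1ccccc1)c1ccc(-c2ccccc2)cc1`, which gives 1.2 nM. Compound 4 `CC[C@H](C)[C@H](N)CN(C(=O)[C@@H]1C[C@H]1c1nccs1)c1ccc(-c2ccccc2)cc1` has not yet been measured. It differs from compound 3 in one place: 1,3-thiazol-2-yl in place of 3-fluorophenyl on a saturated ring carbon. For the measured compounds named here, no measured pair shows this exact change, so its effect cannot be read from the data. With the shared core kept and one aromatic ring replacing another, the change is expected to give a 1.4-fold higher number from compound 3 to compound 4 (0.15 log units; within the scatter), with no clear direction beyond the scatter. Compound 4 is therefore estimated at 800 nM, within a range from 200 nM to 4000 nM.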

Compound 4, half-maximal effective concentration: 210 nM
Estimate against measurement, compound 4: 3.8-fold (0.58 log units) above; low and high end bracket the measured number.
By their numbers in this assay, from the lowest: compounds 1 and 2 (each within the scatter of the next); then compound 4; then compound 3.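

In this assay the exchange of 3-fluorophenyl for 1,3-thiazol-2-yl on the cyclopropane gives a 2.7-fold lower number from compound 3 to compound 4 (0.43 log units; beyond the scatter) and so a modest step beyond the scatter. Among the compounds shown here, this is the first direct reading at this position: with the shared core kept, a five-membered aromatic ring with two hetero atoms serves at least as well as the fluorinated six-membered ring. Nothing measured here explains the change. As far as these compounds go, whether 1,3-oxazol-2-yl or pyridin-2-yl would read the same at this position remains open. So does whether the thiazole step carries over to the core of compound 2.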